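Propyl to ethyl on compound 1

The source may hold more compounds than are shown below. What is called first, only, known or untested is meant among the compounds shown, and "the series" means these compounds.

In a functional assay on K562 cells (Homo sapiens) (on this read-out higher numbers stand for weaker inhibition and lower numbers for stronger inhibition), compound 1 (`CCCNC(=O)Nc1ccc(C(C)(C)C)cc1`) gives 30000 nM as the lowest of three numbers at hand. Compound 2 (`CCNC(=O)Nc1ccc(C(C)C)cc1`) stands at 142000 nM and compound 3 (`CCC(C)c1ccc(NC(=O)NC)cc1`) at 142000 nM with no gap between them, both beyond the scatter from compound 1. Compound 4 (`CCNC(=O)Nc1ccc(C(C)(C)C)cc1`) is unmeasured and differs from compound 1 by hydrogen in place of methyl on a saturated chain carbon, two bonds along the chain from an amide-type nitrogen as hydrogen in place of methyl on a saturated chain carbon, two bonds along the chain from an amide-type nitrogen. Within the data shown here, no measured pair isolates this change. Compound 2 also carries ethyl and stands at 142000 nM but differs elsewhere too. A modest rise is expected in this assay with the estimated step of a 2.2-fold higher number from compound 1 to compound 4 (0.34 log units; beyond the scatter) near the edge of the scatter. Compound 4 is expected at 65000 nM within a range of 30000 nM to 140000 nM on this read-out.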

Compound 4, half-maximal inhibitory concentration: 84000 nM
Compound 4: middle estimate off by 1.3-fold (0.11 log units), on the low side; measured number inside the range.
By their numbers in this assay, from the lowest: compound 1; then compounds 4, 2 and 3 (each within the scatter of the next).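

In this assay the shortening of propyl to ethyl is now isolated in a single pair and gives a 2.8-fold higher number from compound 1 to compound 4 (0.45 log units; beyond the scatter) as a modest step beyond the scatter. Methyl in place of hydrogen on a saturated chain carbon bound to an aromatic carbon and two saturated chain carbons gives a 1.7-fold lower number from compound 2 to compound 4 (0.23 log units; within the scatter) and does not separate those two compounds. No data on hand explain either step.

From the compounds shown here alone, how a butyl chain, or an amine or carboxylic acid on the end of the propyl chain, would read stays open. Whether the propyl to ethyl step holds on other cores is also unresolved.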